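From Pyridin-3-yl to Phenyl on the Shared Core

A few compounds are considered here, and "the series" means these few. Any claim that something is new, unique, unknown or untested is made for them only; others in the source may bear on it.

In a physicochemical assay for solubility (a higher number here means a more soluble compound, a lower number a less soluble compound), the measured compounds read as follows:
Compound 1 `CNC(=O)c1cc(C(=O)NC)c(=O)n(Cc2ccccc2)c1` gives >= 118 ug/mL as a limit
Compound 2 `CNC(=O)c1cc(C(=O)NC2CCC2)cn(Cc2ccccn2)c1=O` gives >= 103 ug/mL as a limit
Compound 3 `CNC(=O)c1cc(C(=O)NC2CCC2)cn(Cc2cccnc2)c1=O` gives >= 99 ug/mL as a limit

Compound 3 stands at the limit >= 99 ug/mL and has no exact number. Among the measured compounds shown here, the other two readings are limits as well, so no compound here can be ranked against another.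

Compound 4 `CNC(=O)c1cc(C(=O)NC2CCC2)cn(Cc2ccccc2)c1=O` is still to be measured. It has phenyl in place of pyridin-3-yl on a saturated chain carbon bound to an aromatic nitrogen and is otherwise the same as compound 3.

The nearest measured change sits at the same place, and it is a step that the two limits leave unreadable from compound 2 to compound 3 so it offers no size to carry over. Compound 1 also bears phenyl at that place, though it differs elsewhere, and it reports the limit >= 118 ug/mL as its reading. The expected change is an at least 1.1-fold lower number from compound 3 to compound 4 (0.04 log units; that floor lies within the scatter) and no step beyond the scatter is expected in this assay in either direction. Compound 4 is estimated at 90 ug/mL with an expected range from 40 ug/mL to 125 ug/mL and may itself return only a limit.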

Compound 4, solubility: 28 ug/mL
Compound 4: the middle estimate sits 3.2-fold (0.51 log units) above what was measured; measured number below the stated range.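

In this assay, phenyl in place of pyridin-3-yl on a saturated chain carbon bound to an aromatic nitrogen gives an at least 3.5-fold lower number from compound 3 to compound 4 (0.54 log units; beyond the scatter), and phenyl in place of pyridin-2-yl at the same place gives an at least 3.6-fold lower number from compound 2 to compound 4 (0.56 log units; beyond the scatter), so this place now carries a readable step beyond the scatter, which the two pyridines alone could not show. Phenyl at this place does not by itself fix the reading, as cyclobutyl in place of methyl on an amide-type nitrogen, with phenyl present on both sides, gives an at least 4.2-fold lower number from compound 1 to compound 4 (0.62 log units; beyond the scatter). Each of these sizes is only a floor because the starting compound stands at a limit, as compound 3 does: the limit of >= 99 ug/mL in this assay, at which 1 of the 4 values shown sits.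

The step between compound 2 and compound 3 cannot be read, so the compounds shown do not tell whether the two pyridines differ from each other in this assay. They also leave open how a phenyl carrying an amine or a carboxylic acid, or a longer chain in place of the single saturated chain carbon, would read against compound 4 on the shared core.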